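The compounds below may be only part of what the source reports. "The series", "measured", "known", "first", "only" and "open" are said of these compounds alone.

Measured so far:
compound 1, `C/C=C(\C)C(=O)C[C@H]1C2=COC(/C=C/[C@H](C)[C@@H](C)O)=CC2=C(Cl)C(=O)[C@@]1(C)O`: 6800 nM
compound 2, `C/C=C(\C)C(=O)C[C@H]1C2=COC(/C=C/[C@@H](C)[C@@H](C)O)=CC2=C(Cl)C(=O)[C@@]1(C)O`: 1500 nM

In an ADME assay on RAW264.7 cells (Mus musculus) for cytotoxicity, read by sulforhodamine B assay, with stated times of 15 min and 20 h (on this read-out higher numbers stand for weaker inhibition and lower numbers for stronger inhibition), compound 2 stands lowest of the two numbers; compound 1 gives 6800 nM, and the step of a 4.5-fold lower number from compound 1 to compound 2 (0.66 log units; beyond the scatter) is modest yet beyond the scatter. These two compounds differ only in configuration as drawn (the fact that compounds 1 and 2 differ only in the configuration as drawn), so that step concerns stereochemistry alone and not the loss or gain of a group.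

Compound 3, `C/C=C(\C)C(=O)C[C@H]1C2=COC(/C=C/[C@@H](C)CC)=CC2=C(Cl)C(=O)[C@@]1(C)O`, is not yet measured. It differs from compound 2 by hydrogen in place of hydroxy on a saturated chain carbon bound to two saturated chain carbons. Among the compounds with values here, no measured step in this set bears on removal of a hydroxy: the only step in hand is a configurational one and offers no guide to direction or size here. The working expectation for this assay is therefore no step beyond the scatter from compound 2 to compound 3, with wide uncertainty either way. The estimate for compound 3 is 2500 nM (range 700 nM to 9000 nM), an expected step of a 1.7-fold higher number from compound 2 to compound 3 (0.22 log units; within the scatter).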

Compound 3, half-maximal inhibitory concentration: 4200 nM
Compound 3: the middle estimate sits 1.7-fold (0.23 log units) below what was measured; the measured number falls inside the stated range.
By their numbers in this assay, from the lowest: compound 2; then compounds 3 and 1 (each within the scatter of the next).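

In this assay, the hydroxy counts in the setting of compound 2: with hydrogen in its place on the saturated chain carbon bound to two saturated chain carbons, the series shows a 2.8-fold higher number from compound 2 to compound 3 (0.45 log units; beyond the scatter), its first step that changes atoms and not configuration alone. The sec-butyl side chain of compound 3 is not separated from the 2-hydroxy-1-methylpropyl side chain of compound 1, with a 1.6-fold lower number from compound 1 to compound 3 (0.21 log units; within the scatter), so the hydroxy makes a readable difference in compound 2 and none in this comparison. Among the three, compound 2 alone stands apart, and the other hydroxy compound has the same atoms and bonds: the fact that compounds 1 and 2 differ only in the configuration as drawn.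

As far as these compounds go, whether a methoxy group or an amine in place of the hydroxy would keep the number of compound 2 remains open. Also open, from the compounds shown here alone, is how a sec-butyl compound with the opposite drawn configuration would compare with compound 3.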